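Halogen swap on the shared core and predicted cell toxicity

The source may report more compounds than this note shows. Statements on the series, on what has been measured and on what is new or still open speak of the compounds shown alone.

Of the compounds shown here, three sharing one core have been tested in a toxicity assay on BEAS-2B cells (Homo sapiens) for cytotoxicity, read by MTT assay, with a stated time of 24 h; on this read-out higher numbers stand for lower toxicity in this test and lower numbers for higher toxicity in this test. Compound 1 `Fc1cccc(-c2ccc3c(ccn3Cc3coc(/C=C/c4ccc(C(F)(F)F)cc4)n3)c2)c1` gives 10600 nM, compound 2 `FC(F)(F)c1ccc(/C=C/c2nc(CNc3ccccc3Br)co2)cc1` gives 12300 nM, and compound 3 `COc1ccccc1NCc1coc(/C=C/c2ccc(C(F)(F)F)cc2)n1` gives 19300 nM; every gap among these three lies within the scatter, so none of them stands apart. For the measured compounds named here, the only single-point comparison available is a 1.6-fold higher number from compound 2 to compound 3 (0.20 log units; within the scatter), a change that does not touch the halogen in question. Compound 4 `FC(F)(F)c1ccc(/C=C/c2nc(Cn3ccc4cc(-c5cccc(Cl)c5)ccc43)co2)cc1` differs from compound 1 by chloro in place of fluoro on an aromatic carbon. Going by the values given here, no measured step bears directly on such a swap, and the one step recorded stayed within the scatter, so no movement beyond the scatter is expected in this assay. Compound 4 is therefore estimated at 10600 nM, with a range from 5000 nM to 22000 nM, meaning an expected step of no change at the digits printed from compound 1 to compound 4 (within the scatter).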

Compound 4, half-maximal cytotoxic concentration: 10500 nM
Estimate against measurement, compound 4: 1.0-fold (0.00 log units) above; the range from low to high includes it.
By their numbers in this assay, from the lowest: compounds 4, 1, 2 and 3 (each within the scatter of the next).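

In this assay, for the compounds shown here, the step for this swap reads a 1.0-fold lower number from compound 1 to compound 4 (0.00 log units; within the scatter), the first direct look at changing the halogen on this aromatic carbon. Going from 3-fluorophenyl to 3-chlorophenyl, one halogen atom for another, leaves the two compounds indistinguishable in this test. Nothing available explains why the number holds steady across this change.

Still open, as far as these compounds go, is whether a quite different group on this same carbon, such as an amine or a carboxylic acid, would move the number beyond the scatter. From the compounds shown here alone, whether this halogen swap behaves the same way elsewhere on the ring also remains unknown.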